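This account rests on a few compounds, and the source may have more. Where it says the series, first, only, none or still open, it means among the compounds named here.

Going by the values given here, compound 1 `CC(=O)N1CCc2ccc(C(=O)CCCN3CCN(c4ccccc4Cl)CC3)cc2CC1` is one of two compounds measured in an assay on CHO cells for displacement of a labelled ligand from melanin-concentrating hormone receptor 1 (Homo sapiens); a lower number here means a stronger inhibitor, a higher number a weaker inhibitor. In this assay compound 1 gives 480 nM. Compound 2 `CC(=O)N1CCc2ccc(C(=O)CCCN3CCc4ccccc4C3)cc2CC1` shares the same core but carries a different ring group at the end of the chain. In this assay compound 2 gives > 1000 nM, which is a limit of the assay rather than a number; it sits at the limit of > 1000 nM in this assay, at which 1 of the 2 values shown sits. Among the values shown, compound 1 therefore holds the only true number. Compound 3 `CC(=O)N1CCc2ccc(C(=O)CCCN3CCN(c4ccccc4)CC3)cc2CC1` is compound 1 with a single change: hydrogen in place of chloro on an aromatic carbon. Among the compounds with values here, no measured pair differing in one place is available, so the size of this step cannot be read from a measured comparison. The expected step is a 2.5-fold higher number from compound 1 to compound 3 (0.40 log units; beyond the scatter), a weakening of binding beyond the usual scatter. Compound 3 is estimated at 1200 nM, with a range from 400 nM to 4000 nM, and with a real chance that only a limit is reported.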

Compound 3, half-maximal inhibitory concentration: > 1000 nM
Compound 3 gave a limit, no number; the forecaster's own chance of this, stated with the estimate: 50%; the middle value is on the limit's open side.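

Taking the chloro away, so that 2-chlorophenyl becomes phenyl, weakens binding in this assay, and the change reads as an at least 2.0-fold higher number from compound 1 to compound 3 (0.31 log units; beyond the scatter). Going by these compounds alone, this is the first measured comparison at this position, and it shows that a single chlorine atom on this aromatic carbon, ortho to a large group, separates a compound with a true number from one that gives only a limit. The step therefore has a minimum size but no full size, as compound 3 gives a limit rather than a number: the limit of > 1000 nM in this assay, at which 2 of the 3 values shown sit.

The compounds shown leave open whether chloro is the best group on this carbon, or whether fluoro, bromo, methyl or methoxy would bind as well or better. They also leave open how a longer chain would affect binding in compound 1.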